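This account rests on a few compounds, and the source may have more. Where it says the series, first, only, none or still open, it means among the compounds named here.

Compound 1 `O=C(CCl)Nc1ccc(I)cc1` and compound 2 `O=C(CCCl)Nc1ccc(I)cc1` are built on one shared core, while compound 3 `CC(C)(C)c1ccc(CNC(=O)CCCl)cc1` and compound 4 `CC(C)(C)c1ccc(CNC(=O)CCCCl)cc1` are built on another; the difference between the two cores is not broken down here. In a functional assay on M21 cells (Homo sapiens) for antiproliferative activity, with a stated time of 48 h (on this read-out lower numbers stand for stronger inhibition and higher numbers for weaker inhibition), compound 1 gives 5100 nM. In this assay compound 2 gives 20000 nM. Within the data shown here, the single change between these two is chloromethyl in place of chloro on a saturated chain carbon bound to a carbonyl carbon, and on this read-out it made a 3.9-fold higher number from compound 1 to compound 2 (0.59 log units; beyond the scatter), so lengthening the chain by one carbon weakened the effect.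

Compound 3 reaches only a limit of this assay, > 100000 nM, and no number is known for it.

Compound 4 has not yet been measured. It differs from compound 3 by chloromethyl in place of chloro on a saturated chain carbon, two bonds along the chain from a carbonyl carbon. Among the measured compounds shown here, this is the same kind of change as the one from compound 1 to compound 2, though not the same: in the measured pair the chain carbon carrying the change is bound to a carbonyl carbon, whereas in compound 4 it sits two bonds along the chain from a carbonyl carbon. For the measured compounds named here, the only measured step of this kind made the number higher, and compound 3 already sits at the limit, so a step that weakens or leaves the effect out of reach is the expectation. In this assay compound 4 is therefore expected to give roughly 300000 nM, most likely between 100000 nM and 1000000 nM. That estimate means a step that the limit leaves unreadable from compound 3 to compound 4 is expected, because compound 3 stands at the limit of > 100000 nM in this assay, at which 1 of the 3 values shown sits, and the earlier chain extension weakened the effect.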

Compound 4, half-maximal inhibitory concentration: 69000 nM
Compound 4: middle estimate off by 4.3-fold (0.64 log units), on the high side; measured number below the stated range.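

On the core of compound 3, chloromethyl in place of chloro gave an at least 1.4-fold lower number from compound 3 to compound 4 (0.16 log units; that floor lies within the scatter) in this assay, so this change did not carry over with the same effect from the core of compound 1, where the same swap weakened the effect: the same change on two cores in this assay, a 3.9-fold higher number (0.59 log units; beyond the scatter) from compound 1 to compound 2 and an at least 1.4-fold lower number (0.16 log units; that floor lies within the scatter) from compound 3 to compound 4, at least 5.6-fold (0.75 log units) apart, beyond the scatter of two such steps

Compound 3 has no true number, only a limit of the assay, so the full size of its step to compound 4 stays unknown: the limit of > 100000 nM in this assay, at which 1 of the 4 values shown sits.

With a single pair on each core, these results show that the outcome of lengthening the chain differed between these two cores, but they do not show which part of the cores is responsible or how the change would behave on any other core.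

The compounds shown leave open what a longer chain ending in chlorine would do on either core, and so whether the trend on each core would continue beyond these two chain lengths. They also leave open whether the chlorine itself is needed for the effect on cell growth, which an amine or a hydroxyl group at the end of the same chain could help to settle.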